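Shrinking the Ether Ring from Oxane to Oxetane

The compounds below may be only part of what the source reports. "The series", "measured", "known", "first", "only" and "open" are said of these compounds alone.

Two sulfonamides share one core and differ only in the ring attached to the sulfonamide nitrogen through a single chain carbon. Compound 1 `NC(=O)[C@@H](CCC(F)(F)F)N(C[C@H]1CCCCO1)S(=O)(=O)c1ccc(Cl)cc1` carries an oxan-2-yl ring, and in an ADME assay on MDCKII-LE cells (Canis lupus familiaris) for permeability, read by transwell migration, in the apical to basolateral direction (a higher number here means that the compound crosses the layer faster, a lower number that the compound crosses the layer more slowly), compound 1 gives 13.4 10^-6 cm/s. Compound 2 `NC(=O)[C@@H](CCC(F)(F)F)N(C[C@H]1CCCOC1)S(=O)(=O)c1ccc(Cl)cc1` carries an oxan-3-yl ring instead, and in this assay compound 2 gives 18.2 10^-6 cm/s. Going by the values given here, the only measured step, a 1.4-fold higher number from compound 1 to compound 2 (0.13 log units; within the scatter), leaves the two compounds within the scatter of each other, so compound 2 stands at one of two numbers that cannot be told apart. Compound 3 `NC(=O)[C@@H](CCC(F)(F)F)N(C[C@@H]1CCO1)S(=O)(=O)c1ccc(Cl)cc1` is not yet measured; its change from compound 2 is oxetan-2-yl in place of oxan-3-yl on a saturated chain carbon bound to a sulfonamide nitrogen. Among the compounds with values here, the one measured step bears on it only loosely, since it moved the ring's attachment point rather than shrinking the ring. On that slim basis a modest step downward, a 1.4-fold lower number from compound 2 to compound 3 (0.15 log units; within the scatter), is expected, and compound 3 is estimated at 13 10^-6 cm/s, with a range from 6 10^-6 cm/s to 26 10^-6 cm/s.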

Compound 3, apparent permeability: 34.9 10^-6 cm/s
Compound 3: the middle estimate sits 2.7-fold (0.43 log units) below what was measured, outside the stated range (above it).
By their numbers in this assay, from the lowest: compounds 1, 2 and 3 (each within the scatter of the next, the first and the last beyond it).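

In this assay, the oxetan-2-yl ring gives the first separation in this short series that lies beyond the scatter, a 2.6-fold higher number from compound 1 to compound 3 (0.42 log units; beyond the scatter), and that step is modest. Measured against the oxan-3-yl ring, the same four-membered ring stays within the scatter, a 1.9-fold higher number from compound 2 to compound 3 (0.28 log units; within the scatter), so at this place on a saturated chain carbon bound to a sulfonamide nitrogen, oxetan-2-yl can be told apart from oxan-2-yl but not from oxan-3-yl. No measurement at hand offers an explanation for the step from the six-membered ring to the four-membered one. As far as these compounds go, whether an open ether chain or an amine on the same chain carbon would fall within these numbers stays open. So does whether the opposite configuration at the stereocentre of the oxetan-2-yl group would give a similar number.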